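From sec-Butyl to Butyl on the Amine Nitrogen

The compounds below may be only part of what the source reports. "The series", "measured", "known", "first", "only" and "open" are said of these compounds alone.

In an ADME assay on Caco-2 cells (Homo sapiens) for inhibition, read by sulforhodamine B assay, with a stated time of 72 h (a lower number here means a stronger inhibitor, a higher number a weaker inhibitor), compound 1 (`CCC(C)NC(=C\C(=O)/C=C/c1ccc(O)c(OC)c1)/C=C/c1ccc(O)c(OC)c1`) gives > 25000 nM as its reading, which is a limit and not a number. Compound 2 (`CCC(C)NC(=C\C(=O)/C=C/c1ccc(O)cc1)/C=C/c1ccc(O)cc1`) gives > 25000 nM as its reading, again a limit. The picture so far is the limit of > 25000 nM in this assay, at which 2 of the 2 values shown sit, and nothing finer, so compound 1 has no exact place on the scale.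

Compound 3 (`CCCCNC(=C\C(=O)/C=C/c1ccc(O)c(OC)c1)/C=C/c1ccc(O)c(OC)c1`) keeps the core of compound 1 and carries butyl in place of sec-butyl on an amine nitrogen. The two have the same atoms, joined differently. Among the compounds with values here, no measured pair shows what a change at this nitrogen does, so the expectation rests on the two limits alone.

With compound 1 reading > 25000 nM as a limit, no step beyond the usual scatter is expected in either direction in this assay from this swap. The expected change is a number no higher from compound 1 to compound 3 (the limit leaves the size open) in this estimate, and the result may well come back as a limit once more. For compound 3 the estimated value is 25000 nM with an expected range from 10000 nM to 50000 nM once it is tested.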

Compound 3, half-maximal inhibitory concentration: > 25000 nM
Compound 3 gave a limit, no number; the forecaster's own chance of this, stated with the estimate: 75%; the middle value sits exactly at the limit.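

In this assay compound 3 gives > 25000 nM as its reading, which is a limit and not a number. Within the data shown here, compound 1 also reads as a limit, so no step from compound 1 to compound 3 can be read. The compounds shown leave open what size of reading any of them truly has, since all sit at one limit: the limit of > 25000 nM in this assay, at which 3 of the 3 values shown sit.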